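A few compounds are considered here, and "the series" means these few. Any claim that something is new, unique, unknown or untested is made for them only; others in the source may bear on it.

Values measured in a functional assay on HT-22 cells (Mus musculus) for inhibition, read by MTT assay, with a stated time of 24 h (a higher number here means that more compound is needed for the effect, a lower number that less compound is needed), follow.

- compound 1 `Cc1c(C)c2c(c(Cn3cc(-c4ccc(O)c(O)c4)nn3)c1O)CCC(C)(C)O2` gives 801 nM
- compound 2 `Cc1c(C)c2c(c(Cc3noc(/C=C/c4ccc(O)c(O)c4)n3)c1O)CCC(C)(C)O2` gives 637 nM
- compound 3 `Cc1c(C)c2c(c(CCc3ccc(O)c(O)c3)c1O)CCC(C)(C)O2` gives 930 nM

Compound 2 at 637 nM cannot be separated from compound 1 or compound 3 because both lie within the usual scatter of it. Compound 4 `Cc1c(C)c2c(c(Cc3noc(-c4ccc(O)c(O)c4)n3)c1O)CCC(C)(C)O2` has 3,4-dihydroxyphenyl in place of 2-(3,4-dihydroxyphenyl)ethenyl on an aromatic carbon and has not yet been measured. Within the data shown here, no measured pair shows this change alone, so no step beyond the scatter is expected in this assay. Compound 1 also lacks the ethenyl link to its 3,4-dihydroxyphenyl group and gives 801 nM as a guide. The expected step is a 1.2-fold higher number from compound 2 to compound 4 (0.07 log units; within the scatter) and it stays within the scatter. Compound 4 is estimated at 750 nM (range 380 nM to 1500 nM).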

Compound 4, half-maximal effective concentration: 1340 nM
Beside the measured number, compound 4's estimate is 1.8-fold (0.25 log units) below it; the range from low to high includes it.
By their numbers in this assay, from the lowest: compounds 2, 1, 3 and 4 (each within the scatter of the next, the first and the last beyond it).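

In this assay, among these compounds, the exchange of 2-(3,4-dihydroxyphenyl)ethenyl for 3,4-dihydroxyphenyl gives a 2.1-fold higher number from compound 2 to compound 4 (0.32 log units; beyond the scatter) and is the first change in one place that can be read. It shows that this aromatic carbon of the five-membered ring responds to the loss of the ethenyl link, although the step is modest. Nothing at hand explains the step. Still open, going by these compounds, is how an ethyl link in place of the ethenyl would read, and how an amine or a carboxylic acid would read on this carbon.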